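Moving the carboxyl from one ring position to another

The compounds below may be only part of what the source reports. "The series", "measured", "known", "first", "only" and "open" are said of these compounds alone.

Measured compounds:
Compound 1, `Cc1c(OCCCCOc2cccc(C(=O)O)c2)ccc(C(=O)CC(C)C)c1C`: 12.1%
Compound 2, `Cc1c(OCCCCOc2cccc(C(=O)O)c2)ccc(C(=O)CC(C)C)c1O`: 84.5%
Compound 3, `CC(=O)c1ccc(OCCCCOc2cccc(C(=O)O)c2C)c(C)c1O`: 79.2%

In an assay on HEK293 cells for positive allosteric modulation of metabotropic glutamate receptor 2 (Rattus norvegicus), read by thallium flux, with a stated time of 2.5 min (a higher number here means a larger maximal response, a lower number a smaller maximal response), compound 1 gives 12.1% and stands lowest of the three measured compounds. Its nearest neighbour, compound 3, gives 79.2%; its furthest, compound 2, gives 84.5%, both gaps lying beyond the scatter. Among the compounds with values here, the one step measured between compounds that differ in a single place, hydroxy in place of methyl on an aromatic carbon, is a number 72.4 percentage points higher from compound 1 to compound 2 (beyond the scatter).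

Compound 4, `Cc1c(OCCCCOc2ccc(C(=O)O)cc2)ccc(C(=O)CC(C)C)c1C`, has not yet been measured in this assay. It differs from compound 1 as follows: 4-carboxyphenyl in place of 3-carboxyphenyl on an oxygen on a saturated carbon

Within the data shown here, no measured step concerns a carboxyphenyl group or its substitution pattern. Among the measured compounds shown here, the step from compound 1 to compound 2 changes a different part of the shared core, so it offers no guide to the step from compound 1 to compound 4. With nothing to rest on, the estimate for compound 4 in this assay stays close to compound 1, at 15% within a range from 5% to 45%. The expected step, a number 2.9 percentage points higher from compound 1 to compound 4 (within the scatter), is therefore small, though the range is kept wide to allow for the absence of any comparable measured change.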

Compound 4, largest response reached (reported as percent of maximum), in percent of the reference or control that the assay uses: 19%
Compound 4: middle estimate off by 4 percentage points, on the low side; low and high end bracket the measured number.
By their numbers in this assay, from the lowest: compounds 1 and 4 (each within the scatter of the next); then compounds 3 and 2 (each within the scatter of the next).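

In this assay, 4-carboxyphenyl in place of 3-carboxyphenyl on an oxygen on a saturated carbon is a number 6.9 percentage points higher from compound 1 to compound 4 (within the scatter), so on the core of compound 1 the two arrangements of the carboxyl cannot be told apart in this read-out. Within the data shown here, this is the only measured exchange at the carboxyphenyl group, and it contrasts with the exchange of hydroxy in place of methyl on an aromatic carbon, which is a number 72.4 percentage points higher from compound 1 to compound 2 (beyond the scatter) and shifts the maximal response far more than the carboxyl's new placement does. Nothing given here accounts for either result.

As far as these compounds go, the finding rests on a single pair with a low maximal response, so it remains open whether 4-carboxyphenyl would also match 3-carboxyphenyl on the hydroxy-bearing core of compound 2, where the response is high. From the compounds shown here alone, it is also open how a tetrazole or a primary amide in place of the carboxylic acid would read at this position.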